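This account rests on a few compounds, and the source may have more. Where it says the series, first, only, none or still open, it means among the compounds named here.

Compound 1, `O=[N+]([O-])c1cn2c(n1)OC[C@@H](NCc1ccc(OC(F)(F)F)cc1F)C2`, gives 0.242 h.
Compound 2, `O=[N+]([O-])c1cn2c(n1)OC[C@@H](NCc1ccc(OC(F)(F)F)cc1Cl)C2`, gives 0.332 h.
Compound 3, `O=[N+]([O-])c1cn2c(n1)OC[C@@H](NCc1ccc(OC(F)(F)F)cc1Oc1ccccc1)C2`, gives 0.107 h.

These three numbers come from an in vitro ADME assay on the whole organism (microsomes, liver, Mus musculus) for metabolic stability, read by LC-MS, with a stated time of 24 h, at a dose of 5 mg/kg by the intravenous route; a lower number here means that the compound disappears faster, a higher number that the compound lasts longer. Among them compound 3 stands lowest: its nearest neighbour is compound 1, separated by the step of a 2.3-fold lower number from compound 1 to compound 3 (0.35 log units; beyond the scatter), and its furthest is compound 2, separated by the step of a 3.1-fold lower number from compound 2 to compound 3 (0.49 log units; beyond the scatter). Compound 1 and compound 2 themselves differ only by the step of a 1.4-fold higher number from compound 1 to compound 2 (0.14 log units; within the scatter).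

Compound 4, `O=[N+]([O-])c1cn2c(n1)OC[C@@H](NCc1ccc(OC(F)(F)F)cc1O)C2`, has not yet been measured. It differs from compound 3 in one place: hydrogen in place of phenyl on an oxygen on an aromatic ring. The same difference, cut one bond further out, reads phenoxy to hydroxy. Among the measured compounds shown here, no measured pair shows a hydroxy on this ring, so the only guide is the two steps in which phenoxy entered, a 2.3-fold lower number from compound 1 to compound 3 (0.35 log units; beyond the scatter) and a 3.1-fold lower number from compound 2 to compound 3 (0.49 log units; beyond the scatter), both modest drops beyond the scatter. Taking the phenyl away again is expected to undo at least part of that drop, so compound 4 is expected to show a modest rise in this assay, a 2.3-fold higher number from compound 3 to compound 4 (0.37 log units; beyond the scatter). Compound 4 is therefore estimated at 0.25 h, with a range from 0.1 h to 0.6 h.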

Compound 4, half-life: 0.238 h
Compound 4: the middle estimate sits 1.1-fold (0.02 log units) above what was measured; low and high end bracket the measured number.
By their numbers in this assay, from the lowest: compound 3; then compounds 4, 1 and 2 (each within the scatter of the next).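

Taking the phenyl off the oxygen in this assay gives a 2.2-fold higher number from compound 3 to compound 4 (0.35 log units; beyond the scatter), a step beyond the scatter, so the short half-life of compound 3 goes with the whole phenoxy group and not with an oxygen on this aromatic carbon as such. The hydroxy compound cannot be told apart from the halogen compounds, with a 1.0-fold lower number from compound 1 to compound 4 (0.01 log units; within the scatter) and a 1.4-fold lower number from compound 2 to compound 4 (0.14 log units; within the scatter) both within the scatter, which means that among the four compounds hydroxy, fluoro and chloro form one group and only phenoxy stands apart. No measurement shown here explains why the phenyl makes this difference.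

A methoxy or a benzyloxy at this place could show whether any carbon group on the oxygen goes with the lower number, or whether this is particular to phenyl. On these data alone, it also remains open whether a phenyl set directly on the aromatic carbon, or an amine in place of the hydroxy, would fall with compound 3 or with the other three compounds.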